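The source may report more compounds than this note shows. Statements on the series, on what has been measured and on what is new or still open speak of the compounds shown alone.

Working notes on the series. Among the compounds with values here, the reference point is compound 1 `CCCCCNC(=O)Nc1c(OCCCn2cnc(-c3ccccc3)c2)cccc1N(C)C`, which in an assay for inhibition of acyl-CoA:cholesterol acyltransferase (Oryctolagus cuniculus), using microsomes (a higher number here means a weaker inhibitor, a lower number a stronger inhibitor), gives 31 nM, the lowest of the three numbers measured so far. Compound 3 `CCCCCNC(=O)Nc1c(OCCCn2cnc(-c3ccccc3)c2C)cccc1N(C)C`, with a methyl in place of hydrogen on an aromatic carbon of the heterocycle, gives 43 nM; the step of a 1.4-fold higher number from compound 1 to compound 3 (0.14 log units; within the scatter) does not leave the scatter. Compound 2 `CCCCCC(=O)Nc1c(OCCCn2cnc(-c3ccccc3)c2)cccc1N(C)C`, with pentyl in place of pentylamino on the carbonyl carbon, gives 200 nM; the step of a 6.5-fold higher number from compound 1 to compound 2 (0.81 log units; beyond the scatter) is the only one in the set that lies beyond the scatter.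

The next compound is compound 4 `CCCCCNC(=O)Nc1c(OCCCn2ncc(-c3ccccc3)n2)cccc1N(C)C`. Relative to compound 1 the change is a group of 11 heavy atoms (8 carbon, 3 nitrogen; one five-membered aromatic ring with 3 hetero atoms, one six-membered aromatic ring of carbon only) in place of a group of 11 heavy atoms (9 carbon, 2 nitrogen; one five-membered aromatic ring with 2 hetero atoms, one six-membered aromatic ring of carbon only), on a saturated chain carbon, three bonds along the chain from an oxygen on an aromatic ring. Neither measured step is the same change. The step from compound 1 to compound 2 concerns the carbonyl region and does not bear on it. From the compounds shown here alone, the step from compound 1 to compound 3 touches the same heterocycle and was within the scatter, so the ring tolerates at least a small edit, but a carbon-for-nitrogen exchange within the ring is untested here.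

On that basis only a small step is expected, a 1.6-fold higher number from compound 1 to compound 4 (0.21 log units; within the scatter), with the direction uncertain. Compound 4 is therefore estimated at 50 nM in this assay, within a range from 15 nM to 200 nM.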

Compound 4, half-maximal inhibitory concentration: 32 nM
For compound 4 the middle estimate is 1.6-fold (0.19 log units) above the measured one; low and high end bracket the measured number.
By their numbers in this assay, from the lowest: compounds 1, 4 and 3 (each within the scatter of the next); then compound 2.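

In this assay, the step of a 1.0-fold higher number from compound 1 to compound 4 (0.01 log units; within the scatter) stays within the scatter, so replacing 4-phenyl-1H-imidazol-1-yl with the group carrying a five-membered aromatic ring with 3 hetero atoms, on a saturated chain carbon, three bonds along the chain from an oxygen on an aromatic ring, leaves the number where it was. Compound 3 had tested only a methyl added to the heterocycle, whereas compound 4 changes the atoms of the ring itself, exchanging a carbon for a nitrogen and going from 2 to 3 hydrogen-bond acceptors, and still no shift beyond the scatter appears at this position. Nothing measured on these compounds accounts for this flat result.

What the compounds shown leave open is how far this tolerance extends, for instance to a carboxylic acid or an amine on the phenyl ring, to a methyl in place of that phenyl, or to a longer chain between the oxygen and the heterocycle. Also open, from the compounds shown here alone, is whether the pentyl replacement of compound 2 would give a similar step when paired with the ring of compound 4.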